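This account rests on a few compounds, and the source may have more. Where it says the series, first, only, none or still open, it means among the compounds named here.

Working notes on the series. In a functional assay on K562 cells (Homo sapiens) for antiproliferative activity, with a stated time of 72 h (on this read-out higher numbers stand for weaker inhibition and lower numbers for stronger inhibition), compound 1 (`OC[C@H]1O[C@@H](n2cnc3c(NCc4cccc(Br)c4)ncnc32)[C@H](O)[C@@H]1O`) gives 19700 nM and compound 2 (`OC[C@H]1O[C@@H](n2cnc3c(NCc4ccc(F)cc4Cl)ncnc32)[C@H](O)[C@@H]1O`) gives 15600 nM. For the measured compounds named here, the only measured step is a 1.3-fold lower number from compound 1 to compound 2 (0.10 log units; within the scatter). Compound 2 therefore stands level with compound 1, and the two cannot be separated on these numbers.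

Compound 3 (`OC[C@H]1O[C@@H](n2cnc3c(NCc4ccc(F)c(Cl)c4)ncnc32)[C@H](O)[C@@H]1O`) is still unmeasured. Its difference from compound 2 is 3-chloro-4-fluorophenyl in place of 2-chloro-4-fluorophenyl on a saturated chain carbon bound to a nitrogen on an aromatic ring. The two have the same atoms, joined differently: 3-chloro-4-fluorophenyl in place of 2-chloro-4-fluorophenyl on a saturated chain carbon bound to a nitrogen on an aromatic ring.

Going by the values given here, the one measured change at this place, a 1.3-fold lower number from compound 1 to compound 2 (0.10 log units; within the scatter), replaced the aryl group and stayed within the scatter. Among the compounds with values here, it is only an indirect guide, since no measured pair isolates this rearrangement of the same atoms. On that single step, no change beyond the scatter is expected in this assay, and no direction is favoured. The estimated step is a 1.1-fold higher number from compound 2 to compound 3 (0.04 log units; within the scatter). For compound 3 the expected value is 17000 nM, with an estimated range of 7000 nM to 40000 nM.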

Compound 3, half-maximal inhibitory concentration: 5500 nM
Beside the measured number, compound 3's estimate is 3.1-fold (0.49 log units) above it, outside the stated range (below it).
By their numbers in this assay, from the lowest: compound 3; then compounds 2 and 1 (each within the scatter of the next).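

In this assay, the rearrangement of the same atoms, 3-chloro-4-fluorophenyl in place of 2-chloro-4-fluorophenyl on a saturated chain carbon bound to a nitrogen on an aromatic ring, gives a 2.8-fold lower number from compound 2 to compound 3 (0.45 log units; beyond the scatter). The substitution pattern on this aryl group therefore affects the read-out, which the earlier replacement of the aryl group did not reveal, and 3-chloro-4-fluorophenyl also separates from 3-bromophenyl, with a 3.6-fold lower number from compound 1 to compound 3 (0.55 log units; beyond the scatter), leaving compound 3 as the most potent of the three in this assay. No available evidence bears on what lies behind this difference.

Going by these compounds, how a phenyl group carrying chlorine alone or fluorine alone would read on this carbon remains open, so the share of each halogen in the step from the 2-chloro-4-fluorophenyl to the 3-chloro-4-fluorophenyl group is unsettled. Also open, on these data alone, is whether a methoxy group or a carboxylic acid on the phenyl ring, or a phenethyl group in place of the benzyl group, would keep, improve or lose the number of compound 3.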